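Replacing 2-chloroquinolin-3-yl on compound 2

The source may report more compounds than this note shows. Statements on the series, on what has been measured and on what is new or still open speak of the compounds shown alone.

Among the compounds with values here, in a physicochemical assay for lipophilicity, measured as octanol-water partition (a lower number here means a more polar compound, a higher number a more lipophilic compound), compound 2 `O=C(NNc1ccnc2cc(Cl)ccc12)c1ccccc1/N=C/c1cc2ccccc2nc1Cl` gives 6 as the highest of the two numbers so far, while compound 1 `O=C(NNc1ccnc2cc(Cl)ccc12)c1ccccc1/N=C/c1ccc(F)cc1` gives 5.18 on the same scale. Compound 3 `O=C(NNc1ccnc2cc(Cl)ccc12)c1ccccc1/N=C/c1cc2ccccc2[nH]c1=O` is still unmeasured and differs from compound 2 in one place. The change is a group of 11 heavy atoms (9 carbon, 1 nitrogen, 1 oxygen; one six-membered aromatic ring of carbon only, one six-membered aromatic ring with 1 hetero atom) in place of a group of 11 heavy atoms (9 carbon, 1 nitrogen, 1 chlorine; one six-membered aromatic ring of carbon only, one six-membered aromatic ring with 1 hetero atom), on a carbon with a double bond to nitrogen and it removes the chlorine, brings in an oxygen and adds a hydrogen-bond donor. Within the data shown here, one measured step bears on this. When 2-chloroquinolin-3-yl came in for 4-fluorophenyl at that same carbon, the result was a number 0.82 log units higher from compound 1 to compound 2 (beyond the scatter) and that is the only guide available. With that group now leaving, a fall somewhat larger than that rise is expected, estimated as a number 1.10 log units lower from compound 2 to compound 3 (beyond the scatter) here. For compound 3 the estimate is 4.9 with an expected range from 4.2 to 5.6 as the likely span.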

Compound 3, partition coefficient: 4.65
Beside the measured number, compound 3's estimate is 0.25 log units above it; the measured number falls inside the stated range.
By their numbers in this assay, from the lowest: compound 3; then compound 1; then compound 2.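

Until now this position had only shown a rise, but the number can also be pushed down here. In this assay, keeping the same count of heavy atoms and the same two aromatic rings, while losing the chlorine and gaining an oxygen and a hydrogen-bond donor, gives a number 1.35 log units lower from compound 2 to compound 3 (beyond the scatter) and this one change is larger than the earlier rise. The new group also falls under 4-fluorophenyl, with a number 0.53 log units lower from compound 1 to compound 3 (beyond the scatter) and no measurement at hand explains either step.

The compounds shown cannot separate what the loss of the chlorine contributes from what the oxygen and the donor contribute. Plain quinolin-3-yl, 2-methoxyquinolin-3-yl and 2-aminoquinolin-3-yl at this carbon would be the groups to tell those contributions apart.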